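A few compounds are considered here, and "the series" means these few. Any claim that something is new, unique, unknown or untested is made for them only; others in the source may bear on it.

In a physicochemical assay for solubility, in phosphate buffer, at pH 6.8 (on this read-out lower numbers stand for lower solubility and higher numbers for higher solubility), compound 1 `CCn1c(NC(C)C)nc2c(C3CCNCC3)csc2c1=O` gives 1100 ug/mL and compound 2 `CCn1c(NC(C)C)nc2c(-c3cncnc3)csc2c1=O` gives 18 ug/mL as the lower of the two numbers. Compound 3 `CCn1c(NC(C)C)nc2c(-c3ccnc(OC)c3)csc2c1=O` carries 2-methoxypyridin-4-yl in place of pyrimidin-5-yl on an aromatic carbon. Going by the values given here, only one measured step bears on this, and only loosely: the large one that put pyrimidin-5-yl in place of piperidin-4-yl (a 61-fold lower number from compound 1 to compound 2 (1.79 log units; beyond the scatter)). Among the compounds with values here, no measured step exchanges one aromatic ring for another, so a much smaller change is expected, toward a lower number (a 2.6-fold lower number from compound 2 to compound 3 (0.41 log units; beyond the scatter)). For compound 3 the estimated value is 7 ug/mL (expected range 2 ug/mL to 22 ug/mL).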

Compound 3, solubility: 2.4 ug/mL
Beside the measured number, compound 3's estimate is 2.9-fold (0.46 log units) above it; low and high end bracket the measured number.
By their numbers in this assay, from the lowest: compound 3; then compound 2; then compound 1.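

In this assay, exchanging one aromatic ring for another at this position still moves the number beyond the scatter: the change to 2-methoxypyridin-4-yl gives a 7.5-fold lower number from compound 2 to compound 3 (0.88 log units; beyond the scatter) and so the aromatic groups are not interchangeable here. Measured from piperidin-4-yl, the same group gives a 460-fold lower number from compound 1 to compound 3 (2.66 log units; beyond the scatter) and this is a larger gap than pyrimidin-5-yl showed. No available evidence accounts for the difference between the two aromatic groups.

The step changes the ring and adds the methoxy together, so their shares stay unseparated. On these data alone, whether pyridin-4-yl without the methoxy, or a 2-aminopyridin-4-yl carrying an amine instead, would fall nearer compound 2 remains open.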